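From bromo to methyl on a benzyl amide

A few compounds are considered here, and "the series" means these few. Any claim that something is new, unique, unknown or untested is made for them only; others in the source may bear on it.

Of the compounds shown here, three sharing one core have been measured in a functional assay on A2780 cells (Homo sapiens) for antiproliferative activity, read by resazurin assay, with a stated time of 72 h (on this read-out lower numbers stand for stronger inhibition and higher numbers for weaker inhibition), and they differ only in the group on the amide-type nitrogen. Compound 1 `CN(C(=O)c1cc2c(Cc3ccccc3)n[nH]c2cc1O)c1ccco1`, carrying furan-2-yl, gives 2500 nM. Compound 2 `Cc1ccccc1CN(C)C(=O)c1cc2c(Cc3ccccc3)n[nH]c2cc1O`, carrying 2-methylbenzyl, gives 4400 nM. Compound 3 `CN(Cc1ccc(Br)cc1)C(=O)c1cc2c(Cc3ccccc3)n[nH]c2cc1O`, carrying 4-bromobenzyl, gives 2800 nM. On these numbers compound 3 cannot be separated from the other two.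

Compound 4 `Cc1ccc(CN(C)C(=O)c2cc3c(Cc4ccccc4)n[nH]c3cc2O)cc1` changes one thing in compound 3: methyl in place of bromo on an aromatic carbon. This is methyl in place of bromo on an aromatic carbon, para to a large group, so 4-bromobenzyl becomes 4-methylbenzyl.

Among the measured compounds shown here, no measured pair makes exactly this swap, so the evidence is indirect. The closest case is a 1.6-fold lower number from compound 2 to compound 3 (0.20 log units; within the scatter), where bromo and methyl also trade places, though the methyl sits elsewhere on the ring. Larger replacements moved the number just as little, with a 1.8-fold higher number from compound 1 to compound 2 (0.25 log units; within the scatter) and a 1.1-fold higher number from compound 1 to compound 3 (0.05 log units; within the scatter). All three steps stay small, so no shift beyond the scatter is expected in this assay, and no direction can be favoured. The estimated step is a 1.1-fold higher number from compound 3 to compound 4 (0.06 log units; within the scatter). Compound 4 is expected at about 3200 nM, with an estimated range of 1700 nM to 6000 nM.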

Compound 4, half-maximal inhibitory concentration: 6900 nM
For compound 4 the middle estimate is 2.2-fold (0.33 log units) below the measured one; the whole stated range lies below it.
By their numbers in this assay, from the lowest: compounds 1, 3, 2 and 4 (each within the scatter of the next, the first and the last beyond it).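

In this assay, among the compounds shown here, the swap of a single heavy atom gives a 2.5-fold higher number from compound 3 to compound 4 (0.39 log units; beyond the scatter), so this place on the ring, para to a large group, is not as indifferent as the earlier steps suggested, though the step is modest. The other two comparisons sharpen this: moving the methyl gives a 1.6-fold higher number from compound 2 to compound 4 (0.20 log units; within the scatter), so 4-methylbenzyl and 2-methylbenzyl cannot be told apart, whereas replacing furan-2-yl with 4-methylbenzyl gives a 2.8-fold higher number from compound 1 to compound 4 (0.44 log units; beyond the scatter), a separation that neither 2-methylbenzyl nor 4-bromobenzyl showed against furan-2-yl. Nothing available here explains the difference between bromo and methyl at this place.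

The compounds shown do not settle whether bromo lowers the number or methyl raises it, since a plain benzyl group, with only hydrogen at this place, would be needed as the reference. Chloro, methoxy or an amine at the same place would then show whether the step is specific to these two groups or part of a wider trend.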